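Amino for chloro on a shared core in UO-31 cells

The compounds below may be only part of what the source reports. "The series", "measured", "known", "first", "only" and "open" are said of these compounds alone.

Compound 1 `Nc1nc(Cl)c2ncn(Cc3ccc(CCl)cc3)c2n1`: 11800 nM
Compound 2 `ClCc1cccc(Cn2cnc3c(Cl)nc(Cl)nc32)c1`: 1580 nM
Compound 3 `ClCc1ccc(Cn2cnc3c(Cl)nc(Cl)nc32)cc1`: 19500 nM

Three compounds were measured in a functional assay on UO-31 cells (Homo sapiens) for cytotoxicity, read by sulforhodamine B assay, with a stated time of 48 h; a higher number here means a weaker inhibitor of growth, a lower number a stronger inhibitor of growth. Compound 3 `ClCc1ccc(Cn2cnc3c(Cl)nc(Cl)nc32)cc1` gives 19500 nM and compound 1 `Nc1nc(Cl)c2ncn(Cc3ccc(CCl)cc3)c2n1` gives 11800 nM. The two differ by one change, (amino in place of chloro on an aromatic carbon), and the step of a 1.7-fold lower number from compound 3 to compound 1 (0.22 log units; within the scatter). Compound 2 `ClCc1cccc(Cn2cnc3c(Cl)nc(Cl)nc32)c1` gives 1580 nM, the lowest of the three numbers and beyond the scatter from both others, so it is the strongest inhibitor of growth among those measured. The difference between the core of compound 2 and the core of compound 3 is not broken down here.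

Compound 4 `Nc1nc(Cl)c2ncn(Cc3cccc(CCl)c3)c2n1` has not yet been measured in this assay. It differs from compound 2 by amino in place of chloro on an aromatic carbon, the same change as that from compound 3 to compound 1, at a place described in the same words. The step is expected to be a 1.3-fold lower number from compound 2 to compound 4 (0.12 log units; within the scatter), resting on the earlier step of a 1.7-fold lower number from compound 3 to compound 1 (0.22 log units; within the scatter), which stayed within the scatter. Compound 4 is therefore estimated at 1200 nM, with a range from 400 nM to 3600 nM.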

Compound 4, concentration for 50% growth inhibition: 13500 nM
Beside the measured number, compound 4's estimate is 11-fold (1.05 log units) below it; the measured number lies above the stated range.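

Amino in place of chloro gives an 8.5-fold higher number from compound 2 to compound 4 (0.93 log units; beyond the scatter) in this assay and so does not carry over as one fixed step between these two cores. Set beside the earlier step, the new one does not agree with it: the same change on two cores in this assay, a 1.7-fold lower number (0.22 log units; within the scatter) from compound 3 to compound 1 and an 8.5-fold higher number (0.93 log units; beyond the scatter) from compound 2 to compound 4, 14-fold (1.15 log units) apart, beyond the scatter of two such steps. The same change therefore has a different outcome on the core of compound 2 and on the core of compound 3, but two pairs give no rule for any further core, and these numbers do not show what underlies the difference.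

The compounds shown leave open how a methylamino or a methoxy group in place of the chloro would behave on either core, and whether such a group would follow the pair ending in compound 1 or the pair ending in compound 4. They also leave open whether the same split between the two cores would appear in any other cell line.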